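Working notes: aryl variation on the shared core

The compounds below may be only part of what the source reports. "The series", "measured", "known", "first", "only" and "open" are said of these compounds alone.

Measured so far in a functional assay on HepG2 cells (Homo sapiens) for antiproliferative activity, read by MTT assay, with a stated time of 48 h; on this read-out lower numbers stand for stronger inhibition and higher numbers for weaker inhibition:
- compound 1 `CCOC(=O)CN(Cc1ccccc1)c1nc(NCc2ccccc2)ncc1[N+](=O)[O-]`: 21000 nM
- compound 2 `CCOC(=O)CN(Cc1ccccc1)c1nc(Nc2ccccc2)ncc1[N+](=O)[O-]`: 44400 nM

Among the compounds with values here, compound 2 holds the highest of the two numbers in this assay; its nearest neighbour is compound 1, and the only measured step, a 2.1-fold higher number from compound 1 to compound 2 (0.33 log units; beyond the scatter), is the change of benzyl to phenyl on a nitrogen on an aromatic ring.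

Compound 3 `CCOC(=O)CN(Cc1ccccc1)c1nc(Nc2cc(OC)c(OC)c(OC)c2)ncc1[N+](=O)[O-]` is the next point in the series. It differs from compound 2 by 3,4,5-trimethoxyphenyl in place of phenyl on a nitrogen on an aromatic ring. Within the data shown here, no measured step touches substitution on that aryl ring itself: the one step known concerns the swap of benzyl for phenyl, not decoration of the phenyl. That step was modest, and the pair shows that changes at this nitrogen move the number only moderately. For compound 3 a small change at most is therefore expected in this assay, with no firm direction, and the step of a 1.4-fold lower number from compound 2 to compound 3 (0.14 log units; within the scatter) is an estimate only. Compound 3 is expected to give about 32000 nM, within 11000 nM to 95000 nM.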

Compound 3, half-maximal inhibitory concentration: 37800 nM
Compound 3: middle estimate off by 1.2-fold (0.07 log units), on the low side; the range from low to high includes it.
By their numbers in this assay, from the lowest: compounds 1, 3 and 2 (each within the scatter of the next, the first and the last beyond it).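

In this assay, within the data shown here, the 3,4,5-trimethoxyphenyl group gives the first reading of a change on the aryl ring itself, a 1.2-fold lower number from compound 2 to compound 3 (0.07 log units; within the scatter), so this decoration of the phenyl on the nitrogen leaves compound 3 indistinguishable from compound 2 in this read-out. Set against the benzyl group, the same aryl group gives a 1.8-fold higher number from compound 1 to compound 3 (0.26 log units; within the scatter), which places compound 3 within the scatter of both compound 1 and compound 2, even though those two are separated by a 2.1-fold higher number from compound 1 to compound 2 (0.33 log units; beyond the scatter); at this position, the trimethoxy decoration therefore neither clearly joins the benzyl compound nor clearly stays with the phenyl compound. No evidence is available to explain these readings.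

The compounds shown leave open whether a single methoxy group, a halogen or an amine on the phenyl ring would give a step beyond the scatter, and whether the 3,4,5-trimethoxy pattern would behave in the same way on the benzyl group of compound 1. They also leave open how a longer chain between this nitrogen and the aryl ring, or a carboxylic acid in place of the ethyl ester, would read in this assay.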